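This account rests on a few compounds, and the source may have more. Where it says the series, first, only, none or still open, it means among the compounds named here.

Measured in a functional assay on MCF7 cells (Homo sapiens) for cytotoxicity, read by MTT assay, with a stated time of 72 h; on this read-out higher numbers stand for weaker inhibition and lower numbers for stronger inhibition:

compound 1, `Cn1ccc2c(Oc3ccc(NC(=O)c4nn(-c5ccc(Br)cc5)ccc4=O)cc3)ccnc21`: 16300 nM
compound 2, `Cn1ccc2c(Oc3ccc(NC(=O)c4nn(-c5ccccc5)ccc4=O)cc3)ccnc21`: 45200 nM
compound 3, `Cn1ccc2c(Oc3ccc(NC(=O)c4nn(-c5ccc(Br)cc5)ccc4=O)cc3F)ccnc21`: 33600 nM

Compound 1 is the lowest of the three numbers. From compound 1 to compound 2 the change is hydrogen in place of bromo on an aromatic carbon and the step is a 2.8-fold higher number from compound 1 to compound 2 (0.44 log units; beyond the scatter). From compound 1 to compound 3 the change is fluoro in place of hydrogen on an aromatic carbon and the step is a 2.1-fold higher number from compound 1 to compound 3 (0.31 log units; beyond the scatter). Compound 2 and compound 3 are within the scatter of each other.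

Compound 4, `Cn1ccc2c(Oc3ccc(NC(=O)c4nn(-c5ccccc5)ccc4=O)cc3F)ccnc21`, has not been measured. It differs from compound 3 by hydrogen in place of bromo on an aromatic carbon, which is the same change as that from compound 1 to compound 2, at a place described in the same words. The cores of the two pairs differ as told above for compound 1 and compound 3.

For compound 3 to compound 4 the expected step is a 2.7-fold higher number from compound 3 to compound 4 (0.43 log units; beyond the scatter), set beside a 2.8-fold higher number from compound 1 to compound 2 (0.44 log units; beyond the scatter); this rests on that single earlier pair only, so the range is wide and a limit rather than a number is possible at these high values. Compound 4 is therefore estimated at 90000 nM in this assay, between 40000 nM and 200000 nM.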

Compound 4, half-maximal inhibitory concentration: > 60000 nM
Compound 4 gave a limit, no number; the forecaster's own chance of this, stated with the estimate: 25%; the middle value lies beyond the limit too.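

In this assay compound 4 gives > 60000 nM, which is a limit of the assay and not a number. On the fluoro-bearing core, hydrogen in place of bromo gives an at least 1.7-fold higher number from compound 3 to compound 4 (0.25 log units; that floor lies within the scatter), and on the phenyl compounds, fluoro in place of hydrogen gives an at least 1.3-fold higher number from compound 2 to compound 4 (0.12 log units; that floor lies within the scatter), so neither step is a number and each floor stays within the scatter. This shows no reversal of either change on the second core, but it does not show that either change carries over at the same size or at a different one; for the loss of bromo the comparison reads: the same change on two cores in this assay, a 2.8-fold higher number (0.44 log units; beyond the scatter) from compound 1 to compound 2 and an at least 1.7-fold higher number (0.25 log units; that floor lies within the scatter) from compound 3 to compound 4; the limit leaves it open whether they differ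

The compounds shown leave open whether a group other than bromo at the same place, such as chloro, methoxy or an amine, would give a measurable number on the fluoro-bearing core. Going by these compounds alone, they also leave open how the two changes combine, since the only compound carrying both ends in a limit.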